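The source may report more compounds than this note shows. Statements on the series, on what has been measured and on what is new or still open speak of the compounds shown alone.

Measured so far in a functional assay on A549 cells (Homo sapiens) for antiproliferative activity, with a stated time of 5 days; a lower number here means a stronger inhibitor, a higher number a weaker inhibitor:
compound 1 `O=C1C=CC2(C=C1)OCC(=O)N2c1nc(-c2ccc3ncccc3c2)nn1-c1ccccc1`: 170 nM
compound 2 `O=C1C=CC2(C=C1)OCC(=O)N2c1nc(-c2ccc3c(c2)OCCO3)nn1-c1ccccc1`: 170 nM

Within the data shown here, compound 2 stands level with compound 1, the only other measured compound. Compound 3 `O=C1C=CC2(C=C1)OCC(=O)N2c1nc(-c2ccc3ccccc3c2Br)nn1-c1ccccc1` differs from it on an aromatic carbon of the five-membered aromatic ring with 3 nitrogen: 1-bromonaphthalen-2-yl in place of 2,3-dihydro-1,4-benzodioxin-6-yl on an aromatic carbon. Among the measured compounds shown here, the one measured step at this place, no change at the digits printed from compound 1 to compound 2 (within the scatter), lies within the scatter, but neither of its groups carries bromine. It therefore gives only weak guidance, and a modest loss is expected rather than a firm null. The estimated step of a 1.5-fold higher number from compound 2 to compound 3 (0.17 log units; within the scatter) is small and uncertain. For compound 3 the expected value is 250 nM, with an estimated range of 80 nM to 800 nM.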

Compound 3, half-maximal inhibitory concentration: 100 nM
For compound 3 the middle estimate is 2.5-fold (0.40 log units) above the measured one; the measured number falls inside the stated range.
By their numbers in this assay, from the lowest: compounds 3, 1 and 2 (each within the scatter of the next).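

In this assay, putting 1-bromonaphthalen-2-yl on this aromatic carbon of the five-membered aromatic ring with 3 nitrogen gives a 1.7-fold lower number from compound 2 to compound 3 (0.23 log units; within the scatter) and a 1.7-fold lower number from compound 1 to compound 3 (0.23 log units; within the scatter), so the bromine-bearing group holds the same level as both earlier groups. This entering group counts 0 hydrogen-bond acceptors where 2,3-dihydro-1,4-benzodioxin-6-yl counts 2, and the read-out stays within the scatter across that change. Nothing available explains why these groups read alike. Open, as far as these compounds go, is whether naphthalen-2-yl without the bromine, or an amine or a carboxylic acid on this carbon, would stay at this level.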